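From Methoxy to (3-Aminobenzyl)oxy on a Weak Inhibitor

The source may report more compounds than this note shows. Statements on the series, on what has been measured and on what is new or still open speak of the compounds shown alone.

Compound 1 `COc1ccc(OCCOCCNC2CCCC2)cc1`: 99100 nM
Compound 2 `c1ccc(COc2ccc(OCCOCCNc3ccccc3)cc2)cc1`: > 100000 nM

Among the compounds with values here, in a functional assay on SK-OV-3 cells (Homo sapiens) for inhibition, read by CCK-8 assay, with a stated time of 70 h (on this read-out lower numbers stand for stronger inhibition and higher numbers for weaker inhibition), compound 1 gives 99100 nM, the only number among the two values shown. Compound 2 sits at the limit of > 100000 nM in this assay, at which 1 of the 2 values shown sits, a limit rather than a number. Compound 3 `Nc1cccc(COc2ccc(OCCOCCNC3CCCC3)cc2)c1` is not yet measured; it differs from compound 1 by 3-aminophenyl in place of hydrogen on a saturated chain carbon bound to an oxygen on an aromatic ring. Within the data shown here, no measured step of this kind exists, and compound 2 differs from both in more than one place. The step is expected to stay within the scatter, estimated at a 1.4-fold lower number from compound 1 to compound 3 (0.15 log units; within the scatter). Compound 3 is expected to give 70000 nM, between 20000 nM and 150000 nM.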

Compound 3, half-maximal inhibitory concentration: 10800 nM
Compound 3: the middle estimate sits 6.5-fold (0.81 log units) above what was measured; the whole stated range lies above it.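

In this assay, the saturated chain carbon bound to an oxygen on an aromatic ring tolerates more than hydrogen: 3-aminophenyl at this place brings a 9.2-fold lower number from compound 1 to compound 3 (0.96 log units; beyond the scatter). Within the data shown here, with hydrogen as the only group seen there, compound 1 could not show that this place affects the read-out. Nothing measured here accounts for the step.

As far as these compounds go, whether the amine of the 3-aminophenyl group contributes to the step remains open. So does the effect of a plain phenyl, a carboxylic acid or a longer chain at this carbon.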